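Cytotoxicity of a pyrazole-fused urea series: predicting compound 3

The source may hold more compounds than are shown below. What is called first, only, known or untested is meant among the compounds shown, and "the series" means these compounds.

Two compounds of a shared core have been examined in a toxicity assay on HepG2 2.2.15 cells (Homo sapiens) for cytotoxicity, read by CellTiter-Glo; on this read-out lower numbers stand for higher toxicity in this test and higher numbers for lower toxicity in this test. Compound 1 `O=C1CC(c2cnc(C(F)(F)F)s2)CN1c1cnn2c1CN(C(=O)Nc1cc(F)c(F)c(F)c1)C(C1CC1)C2` carries a 4-(2-(trifluoromethyl)thiazol-5-yl)-2-oxopyrrolidin-1-yl group; in this assay compound 1 gives 38500 nM. Compound 2 `CC1(C)CC(=O)N(c2cnn3c2CN(C(=O)Nc2cc(F)c(F)c(F)c2)C(C2CC2)C3)C1` bears a 4,4-dimethyl-2-oxopyrrolidin-1-yl group instead, and in this assay compound 2 gives 115000 nM, the highest of the two numbers, with compound 1 standing at a lower number by a margin beyond the usual scatter.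

Compound 3 `O=C1CC(c2ncccn2)CN1c1cnn2c1CN(C(=O)Nc1cc(F)c(F)c(F)c1)C(C1CC1)C2` has not yet been measured. It differs from compound 2 in one place: 2-oxo-4-(pyrimidin-2-yl)pyrrolidin-1-yl in place of 4,4-dimethyl-2-oxopyrrolidin-1-yl on an aromatic carbon. Among the measured compounds shown here, no step between measured compounds isolates this change, so the expectation rests on the two numbers alone. Since the other member with an aromatic group on the pyrrolidinone, compound 1, gives 38500 nM, a modest move toward lower numbers from compound 2 is expected, of a size that may or may not exceed the scatter, as a 1.9-fold lower number from compound 2 to compound 3 (0.28 log units; within the scatter). In this assay compound 3 is therefore estimated at 60000 nM, within a range from 20000 nM to 160000 nM.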

Compound 3, half-maximal cytotoxic concentration: > 200000 nM
Compound 3: no number, only a limit; the forecaster's own chance of this, stated with the estimate: 20%; middle value at least 3.3-fold (0.52 log units) away from the limit.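

In this assay the result for compound 3 is a limit and not a number: the limit of > 200000 nM in this assay, at which 1 of the 3 values shown sits. Pyrimidin-2-yl in place of 2-(trifluoromethyl)-1,3-thiazol-5-yl on a saturated ring carbon gives an at least 5.1-fold higher number from compound 1 to compound 3 (0.71 log units; beyond the scatter), so at this position an aromatic ring on the pyrrolidinone does not in itself bring the lower number, and the identity of that ring matters in this test. 2-Oxo-4-(pyrimidin-2-yl)pyrrolidin-1-yl in place of 4,4-dimethyl-2-oxopyrrolidin-1-yl on the aromatic carbon gives an at least 1.7-fold higher number from compound 2 to compound 3 (0.24 log units; that floor lies within the scatter), which shows no move toward higher toxicity in this test, although the size of the step stays unsettled.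

The compounds shown leave open whether the lower number of compound 1 goes with its trifluoromethyl group or with the thiazole ring itself, a question that a plain 1,3-thiazol-5-yl or a 2-methyl-1,3-thiazol-5-yl group on the same carbon would address. They also leave open whether a phenyl group or a pyridin-2-yl group at that carbon would stay with compound 3 or fall toward compound 1.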